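A Longer Aryl Chain on the Amide of Compound 1

The source may report more compounds than this note shows. Statements on the series, on what has been measured and on what is new or still open speak of the compounds shown alone.

Compound 1 `CC(C)[C@@H](NC(=O)c1ccc(F)cc1)C(=O)N1CCC(c2ccc(Cl)cc2)CC1` was examined in an assay on THP-1 cells for displacement of a labelled ligand from C-C chemokine receptor type 1 (Homo sapiens) (a higher number here means a weaker inhibitor, a lower number a stronger inhibitor), where compound 1 gives 118 nM. Compound 2 `CC[C@@H](C)[C@@H](NC(=O)CCc1ccccc1)C(=O)N1CCC(c2ccc(Cl)cc2)CC1`, built on the same core but with a different amide group and a different side chain, gives in this assay 66 nM. These two numbers lie within the usual scatter of repeated measurements of this kind, so on this evidence neither compound can be set above the other. Compound 3 `Cc1ccccc1CCC(=O)N[C@@H](C(=O)N1CCC(c2ccc(Cl)cc2)CC1)C(C)C` has not yet been measured. It differs from compound 1 in one place: 2-(2-methylphenyl)ethyl in place of 4-fluorophenyl on a carbonyl carbon. An arylalkyl chain on this carbonyl is already seen to be tolerated, because compound 2 gives 66 nM with such a chain. The expected step of a 1.6-fold lower number from compound 1 to compound 3 (0.20 log units; within the scatter) is therefore small, toward a lower number, and may not exceed the scatter. Compound 3 is estimated to give about 75 nM, with a likely range from 25 nM to 250 nM.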

Compound 3, half-maximal inhibitory concentration: 19 nM
The estimate for compound 3 lay 3.9-fold (0.60 log units) above the measured number; the measured number lies below the stated range.
By their numbers in this assay, from the lowest: compound 3; then compounds 2 and 1 (each within the scatter of the next).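

With only the group on the carbonyl carbon changed, this assay shows a 6.2-fold lower number from compound 1 to compound 3 (0.79 log units; beyond the scatter) as a step beyond the scatter. Compound 1 and compound 2 differ in both the amide group and the side chain, so that pair could not show what this position does alone. This pair shows that the number responds to the group on this carbonyl carbon, and that 2-(2-methylphenyl)ethyl is more than merely tolerated there. Nothing at hand explains why the number falls.

The change brings in the ethyl link and the methyl group and removes the fluorine all at once, and the compounds shown do not separate what each part contributes. On these data alone, how a longer chain, an amine or a carboxylic acid would fare in place of 2-(2-methylphenyl)ethyl on this carbonyl carbon also remains open.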